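A few compounds are considered here, and "the series" means these few. Any claim that something is new, unique, unknown or untested is made for them only; others in the source may bear on it.

The compounds measured so far, each with its result in the functional assay:

compound 1, `CO[C@@]12CCN(C)C[C@H]1[C@H](c1ccc(Cl)cc1)C(C#N)=C(N)O2`, giving 10500 nM
compound 2, `CCN1CC[C@@]2(OC)OC(N)=C(C#N)[C@@H](c3ccc(Cl)cc3)[C@@H]2C1`, giving 14900 nM
compound 3, `CO[C@@]12CCN(Cc3ccccc3)C[C@H]1[C@H](c1ccc(Cl)cc1)C(C#N)=C(N)O2`, giving 18500 nM

All three were run in a functional assay on trachea (Cavia porcellus); a lower number here means a stronger inhibitor, a higher number a weaker inhibitor. Compound 2 gives 14900 nM there, a number that lies among those of its two neighbours: the step of a 1.4-fold higher number from compound 1 to compound 2 (0.15 log units; within the scatter) and the step of a 1.2-fold higher number from compound 2 to compound 3 (0.09 log units; within the scatter) both stay within the scatter, as does the step of a 1.8-fold higher number from compound 1 to compound 3 (0.25 log units; within the scatter). Compound 4, `CCN1CC[C@@]2(OC)OC(N)=C(C#N)[C@@H](c3ccc(OC)cc3)[C@@H]2C1`, differs from compound 2 in one place: methoxy in place of chloro on an aromatic carbon. None of the three measured steps touches this place; all of them concern the group on the amine nitrogen in the ring, and all three are within the scatter. For the measured compounds named here, the data therefore hold nothing on an exchange at the aromatic carbon, and the only guide is the narrow spread of the three numbers. For compound 4 the expected step is a 1.1-fold higher number from compound 2 to compound 4 (0.03 log units; within the scatter), not beyond the scatter. Compound 4 is estimated to give 16000 nM in this assay, within a range from 5000 nM to 50000 nM.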

Compound 4, half-maximal inhibitory concentration: 25500 nM
For compound 4 the middle estimate is 1.6-fold (0.20 log units) below the measured one; low and high end bracket the measured number.
By their numbers in this assay, from the lowest: compounds 1, 2, 3 and 4 (each within the scatter of the next, the first and the last beyond it).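

In this assay, for the compounds shown here, the step of a 1.7-fold higher number from compound 2 to compound 4 (0.23 log units; within the scatter) gives the first reading at the aromatic carbon, since all earlier steps concerned the group on the amine nitrogen in the ring. The change from 4-chlorophenyl to 4-methoxyphenyl brings one more heavy atom and a hydrogen-bond acceptor, yet the two compounds cannot be told apart. This position, like the amine nitrogen, therefore shows no exchange beyond the scatter so far.

The compounds shown leave open whether an amine or a carboxylic acid at this same aromatic carbon would give a step beyond the scatter, and whether methoxy would give a similar step on compound 1 or compound 3. No supporting evidence bears on why compound 2 and compound 4 read alike.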